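The compounds below may be only part of what the source reports. "The series", "measured", "known", "first", "only" and "open" are said of these compounds alone.

Series notes. In a functional assay on HeLa cells (Homo sapiens) for inhibition, read by CCK-8 assay, with a stated time of 48 h (a lower number here means a stronger inhibitor, a higher number a weaker inhibitor), compound 1 (`O=S(=O)(NCCNC(=S)Nc1cccc(Cl)c1)c1ccc(-c2ccccc2OCc2ccccc2)s1`) gives 8400 nM and compound 2 (`O=[N+]([O-])c1cccc(NC(=S)NCCNS(=O)(=O)c2ccc(-c3ccccc3OCc3ccccc3)s2)c1`) gives 12800 nM. These two values lie within the scatter of each other, so compound 2 stands level with the only other measured point.

Compound 3 (`O=C(NCCNS(=O)(=O)c1ccc(-c2ccccc2OCc2ccccc2)s1)Nc1cccc([N+](=O)[O-])c1`) keeps the core of compound 2 and changes one group on an amine nitrogen whose other neighbours are: saturated chain carbon. There, (3-nitrophenyl)carbamoyl enters in place of a group of the same heavy-atom count that holds sulfur: a group of 12 heavy atoms (7 carbon, 2 nitrogen, 3 oxygen; one six-membered aromatic ring of carbon only) in place of a group of 12 heavy atoms (7 carbon, 2 nitrogen, 2 oxygen, 1 sulfur; one six-membered aromatic ring of carbon only), on an amine nitrogen.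

Going by the values given here, only one measured step is available: a 1.5-fold higher number from compound 1 to compound 2 (0.18 log units; within the scatter). That step is nitro in place of chloro on an aromatic carbon, and it stays within the scatter. It is a different change, so it shows only that this one substitution left this assay flat. Among the compounds with values here, no measured pair carries the change now in question, and its direction stays open. No shift beyond the scatter is therefore expected, though the range has to stay wide. The estimated step is a 1.1-fold higher number from compound 2 to compound 3 (0.04 log units; within the scatter). For compound 3 the expected value is 14000 nM, with an estimated range from 5500 nM to 35000 nM.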

Compound 3, half-maximal inhibitory concentration: > 20000 nM
Compound 3: no number, only a limit (the forecaster's own chance of this, stated with the estimate: 10%); at least 1.4-fold (0.15 log units) between middle value and limit.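

In this assay compound 3 carries a limit and not a number, > 20000 nM, and it is the only compound in this short series to do so: the limit of > 20000 nM in this assay, at which 1 of the 3 values shown sits.

On the amine nitrogen, (3-nitrophenyl)carbamoyl in place of the sulfur-holding group of the same heavy-atom count gives an at least 1.5-fold higher number from compound 2 to compound 3 (0.19 log units; that floor lies within the scatter), so the floor of this step does not by itself separate the two compounds. The comparison with the chloro compound gives an at least 2.3-fold higher number from compound 1 to compound 3 (0.37 log units; beyond the scatter); this is the only listed step that passes the scatter, and it shows that a change at this position can move the read-out where nitro in place of chloro on an aromatic carbon left it flat, although that step carries both differences at once.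

From the compounds shown here alone, the true size of the step from the sulfur-holding group to (3-nitrophenyl)carbamoyl stays open, as a limit gives no number to set against the measured values. Also open, going by these compounds, are how (3-chlorophenyl)carbamoyl would read at this position, which would separate the two differences, and how a small acetyl group on the same amine nitrogen would read.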